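Halogen exchange at the para position of the aryl ring

This account rests on a few compounds, and the source may have more. Where it says the series, first, only, none or still open, it means among the compounds named here.

Two members of this series have been measured in a functional assay on HEK293 cells for activation of melanin-concentrating hormone receptor 1 (Homo sapiens), read by inositol phosphate accumulation; on this read-out higher numbers stand for an effect only at larger amounts of compound and lower numbers for an effect already at smaller amounts. Compound 1 `CCCc1cc(N)c2cc(NC(=O)/C=C/c3ccc(F)cc3)ccc2n1` gives in this assay a value of 200 nM. Compound 2 `Nc1cc(C2CCC2)nc2ccc(NC(=O)/C=C/c3ccc(C(F)(F)F)cc3)cc12` differs from compound 1 in more than one place; in this assay compound 2 gives 250 nM. These two numbers lie within the usual scatter of each other, so compound 1 holds the lower of the two without standing apart from compound 2 in any meaningful way.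

Compound 3 `CCCc1cc(N)c2cc(NC(=O)/C=C/c3ccc(Cl)cc3)ccc2n1` is not yet measured. It is obtained from compound 1 by a single change: chloro in place of fluoro on an aromatic carbon of the six-membered aromatic ring of carbon only, para to a large group. For the measured compounds named here, no measured pair shows this exchange on its own, so its size is not anchored by data. Taking compound 1 at 200 nM as the starting point, the step expected from compound 1 to compound 3 in this assay is small, a 1.3-fold lower number from compound 1 to compound 3 (0.12 log units; within the scatter), leaning toward a lower number but not expected to clear the scatter with confidence. Compound 3 is therefore estimated at 150 nM, with a range from 60 nM to 450 nM.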

Compound 3, half-maximal effective concentration: 96 nM
Compound 3: the middle estimate sits 1.6-fold (0.19 log units) above what was measured; low and high end bracket the measured number.
By their numbers in this assay, from the lowest: compound 3; then compounds 1 and 2 (each within the scatter of the next).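

In this assay, for the compounds shown here, the 4-fluorophenyl to 4-chlorophenyl exchange provides the first single-place step, a 2.1-fold lower number from compound 1 to compound 3 (0.32 log units; beyond the scatter), showing that the value responds to the identity of the halogen on this aromatic carbon while the rest of the structure stays the same. The step is modest and rests on a single pair, so it establishes a direction for chloro over fluoro on the core of compound 1, not a trend across the halogens. No accompanying measurement bears on what lies behind this step.

Bromo, methoxy and nitrile on this same aromatic carbon remain open, so it cannot yet be said whether the response extends beyond fluoro and chloro or how closely it depends on the kind of group placed there. Also open, as far as these compounds go, is whether the exchange gives a similar step with a different chain on the core, such as a butyl chain in place of the propyl chain of compound 3.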